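The compounds below may be only part of what the source reports. "The series", "measured", "known", "first", "only" and "open" are said of these compounds alone.

Measured so far in a functional assay on DU-145 cells (Homo sapiens) for cytotoxicity, read by CCK-8 assay; on this read-out higher numbers stand for weaker inhibition and lower numbers for stronger inhibition:
compound 1, `Oc1ccc(-c2cc(-c3cccs3)cc(-c3cccc(O)c3)n2)cc1`: 1890 nM
compound 2, `Oc1ccc(-c2cc(-c3ccsc3)cc(-c3cccc(O)c3)n2)cc1`: 2230 nM
compound 3, `Oc1cccc(-c2cc(-c3cccnc3)cc(-c3ccccc3O)n2)c1`: 5580 nM

Among these three numbers compound 3 stands highest. Compound 2 gives 2230 nM and compound 1 gives 1890 nM; both gaps to compound 3 lie beyond the usual scatter, so compound 3 is the weakest inhibitor of the three. Within the data shown here, the only step between compounds that differ in one place is a 1.2-fold higher number from compound 1 to compound 2 (0.07 log units; within the scatter), a change of one thiophene for the other that leaves the number essentially where it was.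

Compound 4, `Oc1ccc(-c2cc(-c3cccnc3)cc(-c3cccc(O)c3)n2)cc1`, has not yet been measured in this assay. It differs from compound 3 in one place: 4-hydroxyphenyl in place of 2-hydroxyphenyl on an aromatic carbon. Compound 4 keeps the pyridin-3-yl group of compound 3 and carries the 4-hydroxyphenyl group found in compound 1 and compound 2.

Among the measured compounds shown here, no measured step follows a change of the hydroxyphenyl group alone, so the size and direction of the step to compound 4 cannot be read from a matched pair. For the measured compounds named here, the step from compound 1 to compound 2 shows only that a small change at another position stays within the scatter. Compound 4 is expected to land at about 3200 nM, within a range of 1400 nM to 7500 nM. That corresponds to an estimated step of a 1.7-fold lower number from compound 3 to compound 4 (0.24 log units; within the scatter), a modest move toward the numbers of compound 1 and compound 2.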

Compound 4, half-maximal inhibitory concentration: 6390 nM
For compound 4 the middle estimate is 2.0-fold (0.30 log units) below the measured one; the measured number falls inside the stated range.
By their numbers in this assay, from the lowest: compounds 1 and 2 (each within the scatter of the next); then compounds 3 and 4 (each within the scatter of the next).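

Among these compounds, the swap of 2-hydroxyphenyl for 4-hydroxyphenyl on the aromatic carbon next to the ring nitrogen gives the first matched reading at this position in this assay, with a 1.1-fold higher number from compound 3 to compound 4 (0.06 log units; within the scatter), so with pyridin-3-yl present, the two hydroxyphenyl groups cannot be told apart here. Among the compounds shown here, the result also gives the first matched comparisons of pyridin-3-yl with the thiophenes, with the 4-hydroxyphenyl and 3-hydroxyphenyl groups held constant: its replacement of thiophen-3-yl gives a 2.9-fold higher number from compound 2 to compound 4 (0.46 log units; beyond the scatter), and its replacement of thiophen-2-yl gives a 3.4-fold higher number from compound 1 to compound 4 (0.53 log units; beyond the scatter). Both of these steps lie beyond the scatter, whereas the exchange of one thiophene for the other did not, so among these compounds, the number responds to the change from thiophene to pyridine and not to the hydroxyphenyl swap.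

As far as these compounds go, it remains open whether 2-hydroxyphenyl and 4-hydroxyphenyl would also match alongside a thiophene, and whether a methoxyphenyl or an aminophenyl group at the same carbon would shift the number. Nothing given here accounts for either the flat step or the larger ones.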